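Trimming the Sulfonyl Aryl Ring: From Compound 1 to Compound 4

The source may hold more compounds than are shown below. What is called first, only, known or untested is meant among the compounds shown, and "the series" means these compounds.

Three compounds built on one shared core have so far been run in an ADME assay on microsomes from liver (Homo sapiens) for metabolic stability, tested at 2.5 uM; on this read-out lower numbers stand for slow clearance and higher numbers for fast clearance. Compound 1 `O=S(=O)(c1ccc(F)c(Cl)c1)c1cnc2cc(F)ccc2c1-c1ccc(Cl)cc1` gives 0.39 mL/min in this assay. Compound 2 `O=S(=O)(c1ccc(F)cc1)c1cnc2cc(F)c(Cl)cc2c1-c1ccc(Cl)cc1` gives 0.01 mL/min, and compound 3 `N#Cc1cccc(S(=O)(=O)c2cnc3c(F)cccc3c2-c2cccc(Cl)c2)c1` gives 1.11 mL/min. Among these three numbers compound 1 stands second highest: its nearest neighbour is compound 3, whose number is higher, while compound 2 sits far below it with by far the lowest number of the set. Both gaps from compound 1 lie beyond the usual scatter of repeated measurements, so they count as real differences rather than noise.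

The step followed here leads from compound 1 to compound 4 `O=S(=O)(c1cccc(F)c1)c1cnc2cc(F)ccc2c1-c1ccc(Cl)cc1`, which has not yet been measured. The structural change is modest: 3-fluorophenyl in place of 3-chloro-4-fluorophenyl on a sulfonyl sulfur. Everything else in the molecule stays as it is.

Within the data shown here, no two measured compounds differ in only one place, so there is no earlier step of this kind to lean on. Losing the chlorine from the ring on the sulfonyl sulfur is expected to give a small downward step a 1.4-fold lower number from compound 1 to compound 4 (0.14 log units; within the scatter), no larger than the usual scatter. Compound 4 is therefore estimated at 0.28 mL/min, with a likely range from 0.1 mL/min to 0.8 mL/min.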

Compound 4, intrinsic clearance in a liver preparation (reported as CLH), per the amount of preparation that the assay uses: 0.98 mL/min
The estimate for compound 4 lay 3.5-fold (0.54 log units) below the measured number; the whole stated range lies below it.
By their numbers in this assay, from the lowest: compound 2; then compound 1; then compounds 4 and 3 (each within the scatter of the next).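

Among these compounds, this is the first pair in the set that differs in one place only, so the group on the sulfonyl sulfur can now be judged apart from the rest of the molecule. In this assay, 3-fluorophenyl in place of 3-chloro-4-fluorophenyl gives a rise (a 2.5-fold higher number from compound 1 to compound 4 (0.40 log units; beyond the scatter)), which shows that this position matters for the read-out, even though the change costs only one heavy atom and leaves the ring type, the donor and acceptor counts and the neutral charge as they were. No measurement here explains why the number goes up, so the size of the step is all that can be stated.

Because the entering group differs from the leaving one in more than the lost chlorine, this single step cannot show how much of the rise belongs to the chlorine alone. Also open, from the compounds shown here alone, is how the number would respond to an amine, a carboxylic acid or a longer chain such as a butyl group on this ring, and whether the step would keep its size on a different core.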